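The source may report more compounds than this note shows. Statements on the series, on what has been measured and on what is new or still open speak of the compounds shown alone.

For the measured compounds named here, in a functional assay on MCF7 cells (Homo sapiens) for inhibition, read by sulforhodamine B assay, with a stated time of 48 h (on this read-out lower numbers stand for stronger inhibition of growth and higher numbers for weaker inhibition of growth), three compounds sharing one core have numbers so far. Compound 3 `COc1ccc(/C=C/C2(C)C=CC(=O)O2)cc1OC` gives 78900 nM, which lies within the usual scatter of compound 2 `COc1ccc(/C=C/C2(C)C=CC(=O)O2)c(OC)c1` at 43500 nM. Compound 1 `CC1(/C=C/c2ccc(C(F)(F)F)cc2)C=CC(=O)O1` gives 20400 nM, a lower number than that of compound 3, and this gap lies beyond the scatter. Compound 4 `COc1ccc(/C=C/C2(C)C=CC(=O)O2)cc1` is still unmeasured. It differs from compound 3 as follows: hydrogen in place of methoxy on an aromatic carbon, with hydrogen in place of methoxy on an aromatic carbon. Going by the values given here, no measured pair isolates this change, so only a small step towards a lower number, within the scatter, is expected. The expected step is a 1.4-fold lower number from compound 3 to compound 4 (0.16 log units; within the scatter). For compound 4 the estimated value is 55000 nM, with an expected range from 25000 nM to 110000 nM.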

Compound 4, concentration for total growth inhibition: 183000 nM
For compound 4 the middle estimate is 3.3-fold (0.52 log units) below the measured one; the measured number lies above the stated range.
By their numbers in this assay, from the lowest: compound 1; then compounds 2 and 3 (each within the scatter of the next); then compound 4.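

In this assay, putting hydrogen in place of the methoxy ortho to the remaining methoxy group gives a 2.3-fold higher number from compound 3 to compound 4 (0.37 log units; beyond the scatter), so this position does affect growth inhibition. The same kind of change on compound 2 gives a 4.2-fold higher number from compound 2 to compound 4 (0.62 log units; beyond the scatter), so both compounds with a second methoxy have lower numbers than the compound with only one. Methoxy in place of trifluoromethyl gives a 9.0-fold higher number from compound 1 to compound 4 (0.95 log units; beyond the scatter). Nothing measured here explains these steps. Still open, on these data alone, is how an amine or a hydroxyl group at this position would compare.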